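Replacing a Pyrimidine Ring: Expected Change in Unbound Share

This account rests on a few compounds, and the source may have more. Where it says the series, first, only, none or still open, it means among the compounds named here.

Values so far in an ADME assay on a cell-free system (plasma, Homo sapiens); a lower number here means a smaller unbound share, a higher number a larger unbound share of the compound
Compound 1 `CCNC(=O)Nc1nc2cc(-c3cccnc3)c(=O)n(CC)c2s1` gives 0.11
Compound 2 `CCNC(=O)Nc1nc2cc(-c3cncnc3)c(=O)n(C(C)C)c2s1` gives 0.15

Compound 2 stands at 0.15 and compound 1 at 0.11 in this assay and this gap lies within the usual scatter of repeated measurements, so the two cannot be told apart. They also differ in more than one place, which means that no single structural change has a measured step to serve as a guide.

Compound 3 (`CCNC(=O)Nc1nc2cc(-c3ccc(OC)nc3)c(=O)n(C(C)C)c2s1`) has not yet been measured. It matches compound 2 except for one change: it carries 6-methoxypyridin-3-yl in place of pyrimidin-5-yl on an aromatic carbon. The entering group is the larger of the two by its count of heavy atoms. A fall in the unbound share is expected, and the estimated step (a 2.5-fold lower number from compound 2 to compound 3 (0.40 log units; beyond the scatter)) goes somewhat beyond the scatter. Neither measured compound tests this direction directly, so the expectation remains uncertain. For compound 3 the estimated value is 0.06 with an expected range from 0.03 to 0.12 in this measurement.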

Compound 3, unbound fraction: 0.05
The estimate for compound 3 lay 1.2-fold (0.08 log units) above the measured number; the measured number falls inside the stated range.
By their numbers in this assay, from the lowest: compound 3; then compounds 1 and 2 (each within the scatter of the next).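

In this assay, within the data shown here, putting 6-methoxypyridin-3-yl in place of pyrimidin-5-yl gives a 3.0-fold lower number from compound 2 to compound 3 (0.48 log units; beyond the scatter), the first measured step here that comes from a change in one place only. It shows that the unbound share responds to the group on this aromatic carbon, while the rest of the molecule, including the isopropyl group, stays the same. Nothing measured here explains the size or direction of this step.

The change does several things at once: the entering ring holds fewer hetero atoms, it brings a methoxy group, and it is the larger group by heavy atoms, so the compounds shown leave open which of these goes with the lower number, and compound 1 cannot settle this as it differs from compound 3 in more than one place. Also open, as far as these compounds go, is how the unbound share would move with other groups at the same spot of this pyridine ring, such as an amine or a longer ethoxy chain in place of the methoxy group, and whether the step would hold with a different group in place of the isopropyl group.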